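Swapping a benzyl arm for a cyanomethyl arm

The source may hold more compounds than are shown below. What is called first, only, known or untested is meant among the compounds shown, and "the series" means these compounds.

Of the compounds shown here, two of this set have been measured in a functional assay on MCF7 cells (Homo sapiens) for antiproliferative activity, read by MTT assay, with a stated time of 48 h; on this read-out higher numbers stand for weaker inhibition and lower numbers for stronger inhibition. Compound 1 `Cc1ccc(-c2nc(NN)c3cc(Cl)ccc3n2)cc1` gives 3.76 ug/mL. Within the data shown here, compound 2 `Cc1ccc(-c2nc(SCc3ccccc3)c3cc(Cl)ccc3n2)cc1` gives 9.66 ug/mL, the highest of the two numbers; the only measured step, a 2.6-fold higher number from compound 1 to compound 2 (0.41 log units; beyond the scatter), shows that exchanging the aminoamino group for benzylsulfanyl weakened the inhibition modestly. Compound 3 `Cc1ccc(-c2nc(SCC#N)c3cc(Cl)ccc3n2)cc1` differs from compound 2 by cyano in place of phenyl on a saturated chain carbon bound to a sulfur; in other words, the benzyl arm becomes a cyanomethyl arm while the sulfur link and the shared core stay unchanged. Among the measured compounds shown here, no measured step touches this outer part of the molecule, so the data give no pointer in either direction. The change is therefore expected to remain within the scatter, with the step of a 1.1-fold lower number from compound 2 to compound 3 (0.06 log units; within the scatter) taken as the best guess. For compound 3 the estimate in this assay is 8.5 ug/mL, with a plausible range from 3.5 ug/mL to 20 ug/mL.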

Compound 3, half-maximal inhibitory concentration: 3.35 ug/mL
For compound 3 the middle estimate is 2.5-fold (0.40 log units) above the measured one, outside the stated range (below it).
By their numbers in this assay, from the lowest: compounds 3 and 1 (each within the scatter of the next); then compound 2.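

In this assay the outer end of the sulfur arm proves to count: cyano in place of phenyl gives a 2.9-fold lower number from compound 2 to compound 3 (0.46 log units; beyond the scatter) and so moves the number, even though the sulfur link and the shared core stay the same. The sulfur link alone therefore does not set the number, since (cyanomethyl)sulfanyl in place of aminoamino on the aromatic carbon gives a 1.1-fold lower number from compound 1 to compound 3 (0.05 log units; within the scatter) and leaves the two compounds level within the scatter. Nothing measured on these compounds offers a reason for the shift.

Going by these compounds, whether the shift belongs to the nitrile itself or to the loss of the phenyl ring stays open, and a plain methyl or an ethyl on the sulfur would help to separate the two. On these data alone, how a longer chain ending in a carboxylic acid would read on this arm is equally open.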